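Replacing a fluorinated ring with pyridine in a thiazole amide

A few compounds are considered here, and "the series" means these few. Any claim that something is new, unique, unknown or untested is made for them only; others in the source may bear on it.

The compounds share a core carrying an amide linked to a thiazole that bears a pyridine ring. Compound 1 `O=C(Nc1nc(-c2ccccn2)cs1)c1ccccc1Cl` carries a 2-chlorophenyl group on the carbonyl carbon; in an ADME assay on Vero cells (Chlorocebus sabaeus) for cytotoxicity, read by MTT assay, with a stated time of 72 h (on this read-out higher numbers stand for an effect only at larger amounts of compound and lower numbers for an effect already at smaller amounts), compound 1 gives 2000 nM. Compound 2 `O=C(Nc1nc(-c2ccccn2)cs1)c1ccccc1F` carries a 2-fluorophenyl group at the same place, but in this assay compound 2 gives "not determined" (no result reported), so it stands on no number of its own. Compound 3 `O=C(Nc1nc(-c2ccccn2)cs1)c1ccccn1` differs from compound 2 in one respect: pyridin-2-yl in place of 2-fluorophenyl on a carbonyl carbon. Among the measured compounds shown here, because compound 2 has no value, no measured step leads to compound 3; only compound 1, with its 2000 nM, gives an anchor. A step of modest size in this assay is expected, not clearly beyond the scatter, perhaps towards an effect at larger amounts. Compound 3 is estimated to give about 3000 nM, with a likely range from 800 nM to 12000 nM.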

Compound 3, half-maximal effective concentration: 5400 nM
Beside the measured number, compound 3's estimate is 1.8-fold (0.26 log units) below it, and the stated range covers the measured number.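

In this assay the place on the carbonyl carbon now has a measured step: pyridin-2-yl in place of 2-chlorophenyl gives a 2.7-fold higher number from compound 1 to compound 3 (0.43 log units; beyond the scatter) and this modest step lies beyond the scatter. The group on this carbonyl carbon therefore matters for this read-out, with the effect on the cells appearing only at larger amounts of compound 3 than of compound 1. Compound 2 has no number, so its step to compound 3 cannot be read, and no supporting measurement is available to explain the shift.

This single pair cannot show whether the direction of the change would hold for other groups. Also open, as far as these compounds go, is how an amine, a carboxylic acid or a longer carbon chain on this carbonyl carbon would compare.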